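Dropping one drawn stereocentre from compound 1

The source may report more compounds than this note shows. Statements on the series, on what has been measured and on what is new or still open speak of the compounds shown alone.

In a functional assay on HeLa cells (Homo sapiens) for cytotoxicity, read by MTT assay (on this read-out lower numbers stand for stronger inhibition and higher numbers for weaker inhibition), compound 1, `CC(C)=CC[C@@H](OC[C@@H](C)O)C1=CC(=O)c2c(O)ccc(O)c2C1=O`, gives 22500 nM, the lower of the two exact numbers available. Compound 2, `CCCCC(CC(=O)O[C@H](CC=C(C)C)C1=CC(=O)c2c(O)ccc(O)c2C1=O)OC(C)=O`, gives 73500 nM, and the gap between these two values lies beyond the scatter. Compound 3, `CCCCCCC(C)(O)CC(=O)O[C@H](CC=C(C)C)C1=CC(=O)c2c(O)ccc(O)c2C1=O`, gives > 100000 nM, which is a limit of the assay and not a number.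

Compound 4, `CC(C)=CC[C@@H](OCC(C)O)C1=CC(=O)c2c(O)ccc(O)c2C1=O`, differs from compound 1 only in how it is drawn: the two compounds have the same atoms and bonds; at least one stereo element is drawn with a configuration in one of them and without one in the other: 1 of 2 stereo elements differ; a stereocentre at a saturated chain carbon is drawn R in compound 1 and without a configuration in compound 4. The two compounds have the same atoms and bonds, and a stereocentre at a saturated chain carbon is drawn R in compound 1 and without a configuration in compound 4.

Within the data shown here, only one measured step exists, an at least 1.3-fold higher number from compound 2 to compound 3 (0.13 log units; that floor lies within the scatter). It exchanges 1-acetoxypentyl for 1-hydroxy-1-methylheptyl, so it changes the groups themselves and is no direct guide to a change of configuration. Among the measured compounds shown here, the best anchor is therefore compound 1 itself at 22500 nM, and the data hold no pair that differs by configuration alone. The expected change is a 1.1-fold higher number from compound 1 to compound 4 (0.03 log units; within the scatter), which would be no shift beyond the scatter. For compound 4 the estimated value in this assay is 24000 nM, with an expected range from 11000 nM to 50000 nM.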

Compound 4, half-maximal inhibitory concentration: 24700 nM
Compound 4: middle estimate off by 1.0-fold (0.01 log units), on the low side; measured number inside the range.
By their numbers in this assay, from the lowest: compounds 1 and 4 (each within the scatter of the next); then compound 2. At a limit, above all of these: compound 3.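

In this assay removing the drawn configuration at this saturated chain carbon gives a 1.1-fold higher number from compound 1 to compound 4 (0.04 log units; within the scatter) and so leaves the two compounds indistinguishable on this read-out. Among these compounds, this is the first pair that bears on configuration, since the only earlier step exchanged one whole group for another, and it shows that leaving this stereocentre undefined brings no change beyond the scatter in this cell test. It is still not a comparison of one configuration with its opposite, because the pair sets a defined centre against an undefined one, and a clean R against S reading needs both drawn: the fact that one of compounds 1 and 4 is drawn with a defined configuration and the other without, at the place where they differ.

Going by these compounds, whether a compound drawn S at this carbon would stay level with compound 1 remains open, and so does the role of the other stereocentre, the one that stays the same in both compounds. Also open, on these data alone, is what an amine or a carboxylic acid on this same chain would do to the number, given that the two compounds here carry the same atoms and bonds and so say nothing about changing the groups themselves.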